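A few compounds are considered here, and "the series" means these few. Any claim that something is new, unique, unknown or untested is made for them only; others in the source may bear on it.

Compound 1 `C[C@@]1(O)[C@H](O)[C@@H](CO)O[C@H]1n1cnc2c(NO)nc(N)nc21`: in an ADME assay on Vero cells (Chlorocebus sabaeus) for cytotoxicity, with a stated time of 3 days (a higher number here means that more compound is tolerated, a lower number that less compound is tolerated), compound 1 gives > 100000 nM, which is a limit of the assay.
Compound 2 `C=C(OCC)c1nc(N)nc2c1ncn2[C@@H]1O[C@H](CO)[C@@H](O)[C@@]1(C)O`: in this assay compound 2 gives > 100000 nM, again a limit.
Compound 3 `COc1nc(Cl)nc2c1ncn2[C@@H]1O[C@H](CO)[C@@H](O)[C@@]1(C)O`: in this assay compound 3 gives > 100000 nM, also a limit.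

Within the data shown here, the single measured step, a step that the two limits leave unreadable from compound 1 to compound 2, cannot be sized, since both ends are limits. Compound 3 therefore stands at a limit, not at a number, in keeping with the limit of > 100000 nM in this assay, at which 3 of the 3 values shown sit. Compound 4 `COc1nc(O)nc2c1ncn2[C@@H]1O[C@H](CO)[C@@H](O)[C@@]1(C)O` differs from it by hydroxy in place of chloro on an aromatic carbon. Among the measured compounds shown here, no measured step addresses this change, and the one step available is unreadable, so nothing points to a shift beyond the scatter. Compound 4 is accordingly expected to give about 100000 nM in this assay, within 50000 nM to 200000 nM. The expected step from compound 3 to compound 4 is therefore a number no higher from compound 3 to compound 4 (the limit leaves the size open), most likely reported again only as a limit.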

Compound 4, half-maximal cytotoxic concentration: > 100000 nM
Compound 4: no number, only a limit (the forecaster's own chance of this, stated with the estimate: 85%); the middle value lies on the limit itself.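

In this assay, among these compounds, compound 4 gives > 100000 nM, a limit, so no step from compound 3 to compound 4 can be read. The compounds shown leave open what number any of them would actually reach: the limit of > 100000 nM in this assay, at which 4 of the 4 values shown sit.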